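Heteroaryl variation on the sulfonamide nitrogen

A few compounds are considered here, and "the series" means these few. Any claim that something is new, unique, unknown or untested is made for them only; others in the source may bear on it.

Measured compounds:
compound 1, `O=S(=O)(Nc1nccs1)c1ccc(N/C(S)=N\c2ccnc3cc(C(F)(F)F)ccc23)cc1`, 27300 nM
compound 2, `O=S(=O)(Nc1ccccn1)c1ccc(N/C(S)=N\c2ccnc3cc(C(F)(F)F)ccc23)cc1`, 28000 nM
compound 3, `Cc1cc(C)nc(NS(=O)(=O)c2ccc(N/C(S)=N\c3ccnc4cc(C(F)(F)F)ccc34)cc2)n1`, 29500 nM

All three measured compounds share one core and differ only in the heteroaryl group on the sulfonamide nitrogen. In a functional assay on HT-1080 cells (Homo sapiens) for antiproliferative activity, read by sulforhodamine B assay, with a stated time of 48 h (on this read-out lower numbers stand for stronger inhibition and higher numbers for weaker inhibition), compound 1 gives 27300 nM, compound 2 gives 28000 nM and compound 3 gives 29500 nM. Compound 3 cannot be told apart from either neighbour: the steps of a 1.1-fold higher number from compound 1 to compound 3 (0.03 log units; within the scatter) and a 1.1-fold higher number from compound 2 to compound 3 (0.02 log units; within the scatter) are both within the scatter, as is a 1.0-fold higher number from compound 1 to compound 2 (0.01 log units; within the scatter). The three numbers therefore form one band with no ordering that the assay can support.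

Compound 4, `COc1ncnc(NS(=O)(=O)c2ccc(N/C(S)=N\c3ccnc4cc(C(F)(F)F)ccc34)cc2)c1OC`, continues the same variation: 5,6-dimethoxypyrimidin-4-yl in place of 4,6-dimethylpyrimidin-2-yl on a sulfonamide nitrogen. All three measured steps bear on this change, since each swaps one heteroaryl on the sulfonamide nitrogen for another, and none of them moved the number beyond the scatter. Among the compounds with values here, there is no measured step in which a methoxy-bearing ring replaces a methyl-bearing one, so nothing in the data points in a particular direction. The expectation is thus no step beyond the scatter, in either direction, in this assay.

Compound 4 is estimated at 29000 nM, within 12000 nM to 70000 nM. The step this implies, a 1.0-fold lower number from compound 3 to compound 4 (0.01 log units; within the scatter), is an expectation only.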

Compound 4, half-maximal inhibitory concentration: 22800 nM
Compound 4: the middle estimate sits 1.3-fold (0.10 log units) above what was measured; low and high end bracket the measured number.
By their numbers in this assay, from the lowest: compounds 4, 1, 2 and 3 (each within the scatter of the next).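

In this assay, 5,6-dimethoxypyrimidin-4-yl on the sulfonamide nitrogen stays within the scatter of every earlier group, with a 1.3-fold lower number from compound 3 to compound 4 (0.11 log units; within the scatter), a 1.2-fold lower number from compound 2 to compound 4 (0.09 log units; within the scatter) and a 1.2-fold lower number from compound 1 to compound 4 (0.08 log units; within the scatter). Within the data shown here, the band of the earlier compounds therefore also holds for a group with 10 heavy atoms, 2 oxygen atoms and 4 hydrogen-bond acceptors, against 8 heavy atoms, no oxygen and 2 hydrogen-bond acceptors in 4,6-dimethylpyrimidin-2-yl, and none of the four compounds goes against this band. No measurement at hand accounts for how little the number responds to these swaps at this position.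

As far as these compounds go, all four groups are aromatic heterocycles, so it remains open whether a different kind of group on the sulfonamide nitrogen, such as a carboxylic acid, an open-chain amine or a plain phenyl ring, would take the number beyond the scatter of this band. From the compounds shown here alone, it also remains open whether the band persists when the shared core itself is altered, for example when trifluoromethyl is replaced by a nitrile.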